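Series notes: chloro for aminocyclopropyl on the pendant phenyl

A few compounds are considered here, and "the series" means these few. Any claim that something is new, unique, unknown or untested is made for them only; others in the source may bear on it.

Compound 2 `Cn1nc2c(=O)n(CC3(O)CCN(Cc4ccc(-c5ccco5)cc4Cl)CC3)cnc2c1-c1ccc(C2(N)CC2)cc1` gives the lowest of the three numbers in an assay on isolated protein for inhibition of ubiquitin carboxyl-terminal hydrolase 7 (Homo sapiens), with stated times of 30 min and 2 h (on this read-out lower numbers stand for stronger inhibition and higher numbers for weaker inhibition), at 66.1 nM. Within the data shown here, compound 3 `Cn1nc2c(=O)n(CC3(O)CCN(Cc4ccc(-c5cnco5)cc4Cl)CC3)cnc2c1-c1ccc(CN)cc1` sits within the scatter of it at 71.6 nM, while compound 1 `Cn1nc2c(=O)n(CC3(O)CCN(Cc4ccc(-c5n[nH]c(=O)o5)cc4Cl)CC3)cnc2c1-c1ccc(CN)cc1` is further off at 171 nM; the only step measured, a 2.4-fold lower number from compound 1 to compound 3 (0.38 log units; beyond the scatter), concerns the five-membered ring on the chlorophenyl. Compound 4 `Cn1nc2c(=O)n(CC3(O)CCN(Cc4ccc(-c5ccco5)cc4Cl)CC3)cnc2c1-c1ccc(Cl)cc1` differs from compound 2 elsewhere: chloro in place of 1-aminocyclopropyl on an aromatic carbon. Among the measured compounds shown here, no measured step touches this position, so the direction rests on the loss of the 1 hydrogen-bond donor and 1 hydrogen-bond acceptor alone; a higher number is expected, of moderate size, a 4.5-fold higher number from compound 2 to compound 4 (0.66 log units; beyond the scatter). Compound 4 is therefore estimated at 300 nM in this assay, between 80 nM and 1200 nM.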

Compound 4, half-maximal inhibitory concentration: 143 nM
For compound 4 the middle estimate is 2.1-fold (0.32 log units) above the measured one; low and high end bracket the measured number.
By their numbers in this assay, from the lowest: compounds 2, 3, 4 and 1 (each within the scatter of the next, the first and the last beyond it).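

Going from 4-(1-aminocyclopropyl)phenyl to 4-chlorophenyl gives a 2.2-fold higher number from compound 2 to compound 4 (0.34 log units; beyond the scatter) in this assay, the first measured step at this position. The step is modest, so in this pair the 1-aminocyclopropyl group is not required for a value in the same nanomolar range. No measurement on hand bears on the origin of this step.

Still open, going by these compounds, is whether the amine or the three-membered ring carries the difference. An unsubstituted cyclopropyl or a carboxylic acid on this aromatic carbon would test this further.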